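The source may hold more compounds than are shown below. What is called first, only, known or untested is meant among the compounds shown, and "the series" means these compounds.

Among the compounds with values here, only two compounds have results so far in a functional assay on L02 cells (Homo sapiens) for inhibition, read by MTT assay, with a stated time of 72 h (a higher number here means a weaker inhibitor, a lower number a stronger inhibitor), and neither result is an exact number. Compound 1 `C=C(c1cc(Cl)cc(Cl)c1OCc1ccccc1)C1COC2(CCCCC2)OO1` gives > 100000 nM in this assay, which is a limit of the assay. Compound 2 `C=C(c1ccc(F)c(F)c1)C1COC(C)(C)OO1` gives > 100000 nM in this assay, which is also a limit. The whole record so far is therefore (the limit of > 100000 nM in this assay, at which 2 of the 2 values shown sit). Within the data shown here, compound 2 thus stands at the limit, without an exact value from which to measure a change, and no step between two measured compounds is available as a guide.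

Compound 3 `C=C(c1ccc(OC)c(F)c1)C1COC(C)(C)OO1` differs from compound 2 in one place: methoxy in place of fluoro on an aromatic carbon. Methoxy stands in place of fluoro on an aromatic carbon, ortho to a fluoro group and para to a large group.

With only limits to go on, no change beyond the scatter is expected in this assay, and a further limit is the most likely result. The expected step is a number no higher from compound 2 to compound 3 (the limit leaves the size open), an estimate with no firm direction. For compound 3, the estimated value is 100000 nM, with an expected range from 40000 nM to 250000 nM.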

Compound 3, half-maximal inhibitory concentration: > 100000 nM
Compound 3: no number, only a limit; the forecaster's own chance of this, stated with the estimate: 75%; the middle value lies on the limit itself.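

Compound 2 and compound 3 both give only a limit in this assay, not a number, and the step for methoxy in place of fluoro between them cannot be read. The compounds shown leave open whether any change to the shared core would give an exact number in this assay, and the whole record remains one limit: the limit of > 100000 nM in this assay, at which 3 of the 3 values shown sit.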